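The source may report more compounds than this note shows. Statements on the series, on what has been measured and on what is new or still open speak of the compounds shown alone.

Compound 1, `CC(C)(C)C[C@H](N)C(=O)Nc1cc2cc[nH]c(=O)c2cc1Cl`, gives 845 nM in an assay on isolated protein for inhibition of Rho-associated protein kinase 2 (Homo sapiens); a higher number here means a weaker inhibitor, a lower number a stronger inhibitor.
Compound 2, `CN(C)[C@H]1CC[C@@H](C(=O)Nc2cc3cc[nH]c(=O)c3cc2Cl)CC1`, gives 1000 nM in this assay.
Compound 3, `N[C@H]1CC[C@H](C(=O)Nc2cc3cc[nH]c(=O)c3cc2Cl)CC1`, gives 330 nM in this assay.

Among the three measured compounds, compound 3 shows the lowest number: its nearest neighbour is compound 1, and the step of a 2.6-fold lower number from compound 1 to compound 3 (0.41 log units; beyond the scatter) places compound 3 beyond the scatter from compound 1, with 4-aminocyclohexyl in place of 1-amino-3,3-dimethylbutyl on a carbonyl carbon. Among the measured compounds shown here, compound 2 stands further away again, though no single-change step links it to compound 3.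

Compound 4, `N[C@H]1CC[C@@H](C(=O)Nc2cc3cc[nH]c(=O)c3cc2Cl)CC1`, is the next compound. It differs from compound 3 as follows: the two compounds have the same atoms and bonds and differ only in configuration as drawn: 2 of 2 stereo elements differ (all stereocentres are inverted: mirror images); a stereocentre at a saturated ring carbon is drawn r in compound 3 and s in compound 4; a stereocentre at a saturated ring carbon is drawn r in compound 3 and s in compound 4. For the measured compounds named here, no measured step among compounds 1, 2 and 3 involves a change in configuration only, so none of them bears directly on this step; the measured steps all involve a change of group. The expectation therefore rests only on the value of compound 3, with a wide allowance for either direction.

Compound 4 is expected to give 600 nM in this assay, with an estimated range from 150 nM to 3000 nM. The step this estimate implies is expected to be a 1.8-fold higher number from compound 3 to compound 4 (0.26 log units; within the scatter).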

Compound 4, half-maximal inhibitory concentration: 15 nM
The estimate for compound 4 lay 40-fold (1.60 log units) above the measured number; measured number outside the range, below it.
By their numbers in this assay, from the lowest: compound 4; then compound 3; then compounds 1 and 2 (each within the scatter of the next).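

At the ring carbons of the 4-aminocyclohexyl group, configuration alone matters in this assay: inverting both stereocentres gives a 22-fold lower number from compound 3 to compound 4 (1.34 log units; beyond the scatter), a far larger step than the earlier change of group. In this configuration, the amino compound also stands well apart from its dimethylamino counterpart, with a 67-fold lower number from compound 2 to compound 4 (1.82 log units; beyond the scatter), and from the open-chain 1-amino-3,3-dimethylbutyl compound, with a 56-fold lower number from compound 1 to compound 4 (1.75 log units; beyond the scatter). The step between compound 3 and compound 4 can be assigned to configuration and to nothing else: the fact that compounds 3 and 4 differ only in the configuration as drawn.

The compounds shown leave open whether a methylamino group on this ring, between amino and dimethylamino, would keep the low number of compound 4 in this assay. They also leave open how a hydroxyl group, or an aminomethyl group, in place of the amino group would fare in either configuration.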